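Swapping Trifluoromethyl for Chloro on a Diaryl Urea

The source may report more compounds than this note shows. Statements on the series, on what has been measured and on what is new or still open speak of the compounds shown alone.

In a functional assay on HT-29 cells (Homo sapiens) for inhibition, read by sulforhodamine B assay, with a stated time of 48 h, tested at 10 uM (a higher number here means a weaker effect of the compound at the concentration tested, a lower number a stronger effect), compound 2 `COc1cc2cc(Oc3ccc(NC(=O)Nc4ccc(Cl)c(C(F)(F)F)c4)cc3)c(C)nc2cc1OC` gives -24.9%, the lowest of the two numbers measured; compound 1 `COc1cc2cc(Oc3ccc(NC(=O)Nc4ccc(C)cc4)cc3)c(C)nc2cc1OC` gives 115%. Among the compounds with values here, the only measured step, a number 139.9 percentage points lower from compound 1 to compound 2 (beyond the scatter), shows that the ring on the amide-type nitrogen can shift the read-out a long way. Compound 3 `COc1cc2cc(Oc3ccc(NC(=O)Nc4ccc(Cl)c(Cl)c4)cc3)c(C)nc2cc1OC` differs from compound 2 by chloro in place of trifluoromethyl on an aromatic carbon. Within the data shown here, no measured step compares chloro with trifluoromethyl directly, and the 4-chloro on that ring stays in place, so compound 2 at -24.9% is taken as the anchor. The step of a number 14.9 percentage points higher from compound 2 to compound 3 (beyond the scatter) is expected, within the scatter. Compound 3 is estimated at -10%, between -45% and 30%.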

Compound 3, a percentage reported as activity, at one concentration (the size of the read-out at that concentration, not a potency): 10.9%
The estimate for compound 3 lay 20.9 percentage points below the measured number; low and high end bracket the measured number.
By their numbers in this assay, from the lowest: compound 2; then compound 3; then compound 1.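

In this assay, this position proves to matter even with the 4-chloro kept: chloro in place of trifluoromethyl gives a number 35.8 percentage points higher from compound 2 to compound 3 (beyond the scatter) and so loses part of the effect. The 3,4-dichlorophenyl ring still gives a number 104.1 percentage points lower from compound 1 to compound 3 (beyond the scatter) against the 4-methylphenyl ring, so most of the drop seen with compound 2 remains. Nothing measured here gives a reason for the difference between the two groups. Going by these compounds, whether a methoxy or a nitrile on this aromatic carbon would match trifluoromethyl remains open, as does what the ring would do with an amine there.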